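Meta-methyl analogue of compound 3: expected inhibition

The source may report more compounds than this note shows. Statements on the series, on what has been measured and on what is new or still open speak of the compounds shown alone.

Measured compounds:
Compound 1 `Cc1ccc(-n2nc(-c3ccccc3)nc2CNc2ccc(C(=O)NO)cc2)cc1`: 60.7%
Compound 2 `O=C(NO)c1ccc(NCc2nc(-c3ccccc3)nn2-c2ccc(F)cc2)cc1`: 67.6%
Compound 3 `O=C(NO)c1ccc(NCc2nc(-c3ccccc3)nn2-c2ccccc2)cc1`: 72.6%

In an assay on Sf9 cells for inhibition of protein deacetylase HDAC6 (Homo sapiens), read by fluorescence, with a stated time of 40 min, tested at 100 nM (on this read-out higher numbers stand for more inhibition at the one concentration tested (going by the name of the read-out) and lower numbers for less inhibition), compound 3 gives 72.6%, the highest of the three numbers. Compound 2 stands nearest with 67.6%; the step of a number 5 percentage points higher from compound 2 to compound 3 (within the scatter) is within the scatter, so the two cannot be ordered. Compound 1 gives 60.7%, and the step of a number 11.9 percentage points higher from compound 1 to compound 3 (beyond the scatter) is beyond the scatter, a modest gain on removing the methyl. The step of a number 6.9 percentage points higher from compound 1 to compound 2 (within the scatter) is within the scatter.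

Compound 4 `Cc1cccc(-n2nc(-c3ccccc3)nc2CNc2ccc(C(=O)NO)cc2)c1` is to be measured in this assay. It differs from compound 3 by methyl in place of hydrogen on an aromatic carbon, the methyl now sitting meta to the large group. The only measured step that concerns a methyl on this ring is a number 11.9 percentage points higher from compound 1 to compound 3 (beyond the scatter), read in the reverse direction, which would point to a loss of that size; whether a methyl placed meta to the large group behaves like the one in compound 1 is not shown by any measured pair. The expectation is therefore a small drop, a number 8.6 percentage points lower from compound 3 to compound 4 (within the scatter), of a size that may or may not exceed the scatter. Compound 4 is estimated at 64%, with a range from 52% to 76%.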

Compound 4, a percentage reported as inhibition, at one concentration (the size of the read-out at that concentration, not a potency): 66%
For compound 4 the middle estimate is 2 percentage points below the measured one; low and high end bracket the measured number.
By their numbers in this assay, from the lowest: compounds 1, 4, 2 and 3 (each within the scatter of the next, the first and the last beyond it).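

Read in this assay, the change from phenyl to 3-methylphenyl gives a number 6.6 percentage points lower from compound 3 to compound 4 (within the scatter), so the number with a methyl meta to a large group is level with the number without it within the resolution of this read-out, whereas the 4-methylphenyl of compound 1 gave a number 11.9 percentage points higher from compound 1 to compound 3 (beyond the scatter). This does not establish that the position of the methyl matters, since the direct comparison of the two methyl isomers gives a number 5.3 percentage points higher from compound 1 to compound 4 (within the scatter), and 3-methylphenyl in place of 4-fluorophenyl gives a number 1.6 percentage points lower from compound 2 to compound 4 (within the scatter), so compound 4 cannot be ordered against compound 1 or compound 2. No independent evidence bears on why the values fall as they do.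

The compounds shown leave open whether a methoxy group, a chlorine atom, an amine or a carboxylic acid on this aromatic carbon would move the number beyond the scatter from compound 3, since methyl is the only group tested at this place. With a single concentration as the read-out, they also leave open whether potency follows the same pattern across compound 1, compound 2, compound 3 and compound 4.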